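Amide-side cyclopropyl kept, cyclopropyl replacing methyl at the ring nitrogen

A few compounds are considered here, and "the series" means these few. Any claim that something is new, unique, unknown or untested is made for them only; others in the source may bear on it.

Two compounds of this series carry numbers. Compound 1 `CNc1nc(Cl)nc2c1ncn2[C@@H]1O[C@H](C(=O)NC2CC2)[C@@H](O)[C@H]1O` is the cyclopropyl amide; in an assay on CHO cells for displacement of a labelled ligand from adenosine receptor A3 (Homo sapiens) (on this read-out lower numbers stand for stronger inhibition and higher numbers for weaker inhibition), compound 1 gives 2.82 nM, the lowest of the two numbers. Compound 2 `CNc1nc(Cl)nc2c1ncn2[C@@H]1O[C@H](C(=O)NCc2cccc(F)c2)[C@@H](O)[C@H]1O` differs from it only at the amide-type nitrogen, where 3-fluorobenzyl replaces cyclopropyl; compound 2 gives 17.4 nM, and the step of a 6.2-fold higher number from compound 1 to compound 2 (0.79 log units; beyond the scatter) is beyond the scatter.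

Compound 3 `O=C(NC1CC1)[C@H]1O[C@@H](n2cnc3c(NC4CC4)nc(Cl)nc32)[C@H](O)[C@@H]1O` keeps the cyclopropyl amide of compound 1 and changes the other end of the shared core: cyclopropyl in place of methyl on a nitrogen on an aromatic ring, a shift from methylamino to cyclopropylamino. Going by the values given here, no measured step in this assay touches that nitrogen; the single step known, from the amide substituent, shows the series can move by more than the scatter on a one-group change, but it tells nothing about direction here. The expectation is therefore a small to modest rise in the number, not a fall, with wide uncertainty. For compound 3 the estimated step is a 2.8-fold higher number from compound 1 to compound 3 (0.45 log units; beyond the scatter). The estimate for compound 3 in this assay is 8 nM, with a range from 2.5 nM to 30 nM.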

Compound 3, inhibition constant: 5.62 nM
The estimate for compound 3 lay 1.4-fold (0.15 log units) above the measured number; measured number inside the range.
By their numbers in this assay, from the lowest: compounds 1 and 3 (each within the scatter of the next); then compound 2.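

In this assay, this nitrogen accepts the three-membered carbon ring in place of methyl with no change that can be told from the scatter: the step is a 2.0-fold higher number from compound 1 to compound 3 (0.30 log units; within the scatter). Going by these compounds alone, until now the only reading came from the amide-type nitrogen, where the step is a 6.2-fold higher number from compound 1 to compound 2 (0.79 log units; beyond the scatter) and lies beyond the scatter; the step from methylamino to cyclopropylamino, by contrast, stays within it, and gives this position its first reading, on the cyclopropyl amide only. No supporting measurement bears on why the number holds here.

Whether the same change stays within the scatter when 3-fluorobenzyl sits on the amide-type nitrogen remains an open question, since the reading at this position rests on a single pair with one amide group. Also open, from the compounds shown here alone, is how far this nitrogen accepts other substituents, such as ethyl, cyclobutyl, benzyl or a longer alkyl chain, or the plain unsubstituted amine, any of which would show whether the flat step extends beyond cyclopropyl.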